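The source may hold more compounds than are shown below. What is called first, only, known or untested is meant among the compounds shown, and "the series" means these compounds.

Series notes, three amides on one shared core, read in an assay on CHO cells for agonist activity at Neuronal acetylcholine receptor; alpha3/alpha6/beta2/beta3 (Homo sapiens), read by FLIPR and calcium flux; on this read-out lower numbers stand for an effect already at smaller amounts and higher numbers for an effect only at larger amounts of compound. Compound 1 `CCCC(=O)N1CC2CC(C1)N2` gives 300 nM in this assay, the lowest of the three numbers; its nearest neighbour is compound 3 and its furthest compound 2. Compound 2 `O=C(C1CC=CC1)N1CC2CC(C1)N2` gives 1900 nM in this assay. For the measured compounds named here, compound 3 `O=C([C@H]1C[C@@H]1F)N1CC2CC(C1)N2` gives 620 nM in this assay, and the step of a 2.1-fold higher number from compound 1 to compound 3 (0.32 log units; beyond the scatter) is the one measured change that bears on the next pair.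

Compound 4 `O=C([C@@H]1C[C@H]1F)N1CC2CC(C1)N2` is not yet measured. Against compound 1 the change is 2-fluorocyclopropyl in place of propyl on a carbonyl carbon. This is the same group as in compound 3 but with the opposite arrangement at its two defined stereocentres. Going by the values given here, the measured step of a 2.1-fold higher number from compound 1 to compound 3 (0.32 log units; beyond the scatter) is modest and beyond the scatter; no measured pair shows what the reversed arrangement does, so the same direction with a similar size is the working assumption, with a wider range to allow for the unknown stereochemical effect. Compound 4 is therefore expected to show a 2.3-fold higher number from compound 1 to compound 4 (0.37 log units; beyond the scatter), with an estimated value of 700 nM in this assay, in the range 250 nM to 2000 nM.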

Compound 4, half-maximal effective concentration: 53 nM
The estimate for compound 4 lay 13-fold (1.12 log units) above the measured number; measured number below the stated range.
By their numbers in this assay, from the lowest: compound 4; then compound 1; then compound 3; then compound 2.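

The 2-fluorocyclopropyl group on this carbonyl carbon has no single direction against propyl: the arrangement of compound 4 gives a 5.7-fold lower number from compound 1 to compound 4 (0.75 log units; beyond the scatter), opposite in direction to a 2.1-fold higher number from compound 1 to compound 3 (0.32 log units; beyond the scatter). The arrangement of the group therefore decides the direction of the change, and in this assay it alone accounts for a 12-fold lower number from compound 3 to compound 4 (1.07 log units; beyond the scatter), a large step. With atoms and bonds the same in both compounds, the drawn configuration is the only recorded difference behind that gap: the fact that one of compounds 3 and 4 is drawn with a defined configuration and the other without, at the place where they differ

Going by these compounds, how much of the step from propyl belongs to the three-membered ring and how much to the fluorine stays open, and an unsubstituted cyclopropyl group on the same carbonyl carbon would separate the two. Also open, on these data alone, is whether the arrangement of compound 4 keeps its advantage with a methyl group in place of the fluorine.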